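Compound 2 to compound 3: cyano out, acetyl in

The source may hold more compounds than are shown below. What is called first, only, known or untested is meant among the compounds shown, and "the series" means these compounds.

Among the compounds with values here, in a functional assay (aorta) with Oryctolagus cuniculus as the target (on this read-out higher numbers stand for weaker binding and lower numbers for tighter binding), compound 1 (`COc1cc(C(C)O)ccc1OCCCN1CCC(C(c2ccc(F)cc2)c2ccc(F)cc2)CC1`) gives 10 nM and compound 2 (`COc1cc(C#N)ccc1OCCCN1CCC(C(c2ccc(F)cc2)c2ccc(F)cc2)CC1`) gives 2 nM, the lower of the two numbers so far. Compound 3 (`COc1cc(OCCCN2CCC(C(c3ccc(F)cc3)c3ccc(F)cc3)CC2)ccc1C(C)=O`) departs from compound 2 by one change: 4-acetyl-3-methoxyphenyl in place of 4-cyano-2-methoxyphenyl on an oxygen on a saturated carbon. Within the data shown here, only one measured step bears on this: a 5.0-fold lower number from compound 1 to compound 2 (0.70 log units; beyond the scatter), with cyano in place of 1-hydroxyethyl on an aromatic carbon. That step is modest but beyond the scatter. Among the measured compounds shown here, no measured compound carries the 4-acetyl-3-methoxyphenyl group, so the support is indirect. A shift of similar or smaller size is expected in this assay, towards a higher number. The expected step is a 2.5-fold higher number from compound 2 to compound 3 (0.40 log units; beyond the scatter). In this assay the estimate for compound 3 is 5 nM, with an expected range from 1.5 nM to 20 nM.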

Compound 3, dissociation constant: 3.16 nM
For compound 3 the middle estimate is 1.6-fold (0.20 log units) above the measured one; the range from low to high includes it.
By their numbers in this assay, from the lowest: compounds 2 and 3 (each within the scatter of the next); then compound 1.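

In this assay, 4-acetyl-3-methoxyphenyl in place of 4-cyano-2-methoxyphenyl on the oxygen gives a 1.6-fold higher number from compound 2 to compound 3 (0.20 log units; within the scatter), so compound 2 and compound 3 cannot be told apart, although the nitrile is absent from compound 3. Against the 4-(1-hydroxyethyl)-2-methoxyphenyl group, the same entering group gives a 3.2-fold lower number from compound 1 to compound 3 (0.50 log units; beyond the scatter), so the lower numbers in this small set are not tied to the nitrile alone. No measurement at hand explains either step.

The names of the leaving and entering groups differ both in the group at the 4 place and in the number on the methoxy, so the step does not separate these two changes; 4-acetyl-2-methoxyphenyl would do so. From the compounds shown here alone, how a carboxylic acid or an amine in place of the acetyl would read in this assay remains open.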